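The source may report more compounds than this note shows. Statements on the series, on what has been measured and on what is new or still open speak of the compounds shown alone.

Measured in a functional assay on MCF7 cells (Homo sapiens) for antiproliferative activity, read by sulforhodamine B assay, with a stated time of 48 h; on this read-out higher numbers stand for weaker inhibition and lower numbers for stronger inhibition:
- compound 1 `COc1ccccc1OS(=O)(=O)c1ccc(N2CCN(C)C2=O)cc1`: 26000 nM
- compound 2 `COc1cccc(OS(=O)(=O)c2ccc(N3CCN(C)C3=O)cc2)c1`: 3000 nM
- compound 3 `CCN1CCN(c2ccc(S(=O)(=O)Oc3ccccc3OC)cc2)C1=O`: > 100000 nM

Compound 3 sits at the limit of > 100000 nM in this assay, at which 1 of the 3 values shown sits, so it has a limit and not a number. Compound 4 `CCN1CCN(c2ccc(S(=O)(=O)Oc3cccc(OC)c3)cc2)C1=O` has not been measured yet. It differs from compound 3 in one place: 3-methoxyphenyl in place of 2-methoxyphenyl on an oxygen. In words, 3-methoxyphenyl stands in place of 2-methoxyphenyl on an oxygen whose other neighbour is the sulfonyl sulfur.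

The same swap has been measured once, as an 8.7-fold lower number from compound 1 to compound 2 (0.94 log units; beyond the scatter). It is the closest guide, although it is a single example on a core carrying methyl in place of the ethyl group of compound 3. The second measured step, an at least 3.8-fold higher number from compound 1 to compound 3 (0.58 log units; beyond the scatter), shows the other change in the same comparison, and it moved the number upward. Together they suggest that compound 4 should give a clearly lower number than the limit of compound 3, meaning stronger inhibition. Compound 4 is also expected to give a higher number than compound 2, which stands at 3000 nM.

The expected change is an at least 7.1-fold lower number from compound 3 to compound 4 (0.85 log units; beyond the scatter), and its true size stays uncertain without a number at the starting point. For compound 4 the estimate is 14000 nM, with an expected range from 4000 nM to 60000 nM.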

Compound 4, half-maximal inhibitory concentration: 14000 nM
Estimate against measurement, compound 4: no gap at the digits printed; measured number inside the range.
By their numbers in this assay, from the lowest: compound 2; then compounds 4 and 1 (each within the scatter of the next). At a limit, above all of these: compound 3.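

In this assay, 3-methoxyphenyl in place of 2-methoxyphenyl on the oxygen whose other neighbour is the sulfonyl sulfur gives an at least 7.1-fold lower number from compound 3 to compound 4 (0.85 log units; beyond the scatter), so the number falls with this swap on a second core and no longer rests on a single example: the same change on two cores in this assay, an 8.7-fold lower number (0.94 log units; beyond the scatter) from compound 1 to compound 2 and an at least 7.1-fold lower number (0.85 log units; beyond the scatter) from compound 3 to compound 4; the limit leaves it open whether they differ

Compound 3 has only a limit, > 100000 nM, so this step has a minimum size and not an exact one.

Methyl in place of hydrogen on a saturated chain carbon bound to an amide-type nitrogen in a ring gives a 4.7-fold higher number from compound 2 to compound 4 (0.67 log units; beyond the scatter), which puts an exact size on that change and shows it raising the number with 3-methoxyphenyl as well as with 2-methoxyphenyl: the same change on two cores in this assay, an at least 3.8-fold higher number (0.58 log units; beyond the scatter) from compound 1 to compound 3 and a 4.7-fold higher number (0.67 log units; beyond the scatter) from compound 2 to compound 4; the limit leaves it open whether they differ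

The compounds shown leave open how an unsubstituted phenyl or a hydroxyphenyl would behave on that oxygen, and whether a propyl chain in place of the ethyl group would raise the number further. From the compounds shown here alone, the true size of the methoxy swap on the core of compound 3 also stays open, and with it whether that swap matches the step seen on the core of compound 1.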